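Chain Extension on a Fluorinated Indolylpyrimidine Acrylamide

This account rests on a few compounds, and the source may have more. Where it says the series, first, only, none or still open, it means among the compounds named here.

Two compounds define the picture so far. Compound 1 `CCC/C=C\C(=O)Nc1cc(Nc2ncc(C#N)c(-c3cn(C)c4ccccc34)n2)c(OC)cc1N(C)CCN(C)C` carries a pent-1-en-1-yl amide and an unsubstituted indole ring; in a functional assay on NCI-H1975 cells (Homo sapiens) for antiproliferative activity, read by MTT assay, with a stated time of 72 h (a lower number here means a stronger inhibitor, a higher number a weaker inhibitor), compound 1 gives 823 nM. Compound 2 `CC/C=C\C(=O)Nc1cc(Nc2ncc(C#N)c(-c3cn(C)c4ccc(F)cc34)n2)c(OC)cc1N(C)CCN(C)C` carries a but-1-en-1-yl amide and a fluorine on the indole ring; in this assay compound 2 gives 10200 nM, the highest number of the two and well beyond the scatter from compound 1. Compound 1 and compound 2 differ in two places. Their values alone cannot be split between the chain and the fluorine.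

Compound 3 `CCC/C=C\C(=O)Nc1cc(Nc2ncc(C#N)c(-c3cn(C)c4ccc(F)cc34)n2)c(OC)cc1N(C)CCN(C)C` differs from compound 2 in one place: methyl in place of hydrogen on a saturated chain carbon, two bonds along the chain from a double-bonded chain carbon, so the amide chain of compound 3 matches that of compound 1 while the fluorinated indole of compound 2 is kept.

Given only compound 1 at 823 nM as a guide for the longer chain, the expected step from compound 2 to compound 3 is a 2.9-fold lower number from compound 2 to compound 3 (0.46 log units; beyond the scatter), a moderate move toward a lower number, though the fluorine leaves the outcome uncertain. Compound 3 is therefore estimated at 3500 nM, with a range from 900 nM to 13000 nM.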

Compound 3, half-maximal inhibitory concentration: 2420 nM
Estimate against measurement, compound 3: 1.4-fold (0.16 log units) above, and the stated range covers the measured number.
By their numbers in this assay, from the lowest: compound 1; then compound 3; then compound 2.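

In this assay, the change from but-1-en-1-yl to pent-1-en-1-yl, with the fluorine kept, gives a 4.2-fold lower number from compound 2 to compound 3 (0.62 log units; beyond the scatter), so methyl in place of hydrogen on a saturated chain carbon, two bonds along the chain from a double-bonded chain carbon, moves the number down beyond the scatter. With the pent-1-en-1-yl chain kept, fluoro in place of hydrogen on an aromatic carbon gives a 2.9-fold higher number from compound 1 to compound 3 (0.47 log units; beyond the scatter), so each of the two places that separate compound 1 and compound 2 now has a step of its own, and the two steps run in opposite directions on the number. No supporting measurement accompanies these steps to explain either one.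

As far as these compounds go, it remains open whether a longer chain, such as hex-1-en-1-yl, would lower the number further, or whether the chain step would hold on the indole without fluorine. Nor do these compounds show how chloro or methoxy would compare with fluoro on that aromatic carbon, so the reading rests on a single step at each place.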